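Aryl replacement on the shared core: compound 3 to compound 4

The compounds below may be only part of what the source reports. "The series", "measured", "known", "first", "only" and "open" are said of these compounds alone.

Three compounds of the series have been measured in a functional assay on MDA-MB-231 cells (Homo sapiens) for inhibition, read by sulforhodamine B assay, with a stated time of 48 h, tested at 10 uM; on this read-out lower numbers stand for less inhibition and higher numbers for more inhibition at the one concentration tested (going by the name of the read-out):

compound 1, `Brc1cn2ccnc2c(-c2ccc3ncn(C4CCCCC4)c3c2)n1`, gives 24.2%
compound 2, `CC(=O)c1ccc(-c2cn3ccnc3c(-c3ccc4ncn(C5CCCCC5)c4c3)n2)cc1`, gives 7.65%
compound 3, `COc1ccccc1-c1cn2ccnc2c(-c2ccc3ncn(C4CCCCC4)c3c2)n1`, gives 15.9%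

Compound 3 stands second highest of the three numbers; one of its gaps is a number 8.3 percentage points higher from compound 2 to compound 3 (within the scatter), and the other is a number 8.3 percentage points lower from compound 1 to compound 3 (within the scatter), both within the scatter. Going by the values given here, the only step beyond the scatter is a number 16.6 percentage points lower from compound 1 to compound 2 (beyond the scatter).

Compound 4, `FC(F)(F)c1cccc(-c2cn3ccnc3c(-c3ccc4ncn(C5CCCCC5)c4c3)n2)c1`, differs from compound 3 at the same aromatic carbon that carries bromo in compound 1 and the aryl groups in compounds 2 and 3: 3-(trifluoromethyl)phenyl in place of 2-methoxyphenyl on an aromatic carbon.

Among the compounds with values here, two measured steps bear on this position. Both aryl groups in place of bromo left the number at or under that of compound 1, and the swap of one aryl for another, a number 8.3 percentage points higher from compound 2 to compound 3 (within the scatter), stayed within the scatter. A third aryl group at the same carbon is therefore expected to stay near the narrow band spanned by compounds 2 and 3, with no step beyond the scatter; the expected step is a number 3.9 percentage points lower from compound 3 to compound 4 (within the scatter).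

Compound 4 is estimated in this assay at 12%, with a range from 2% to 28%.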

Compound 4, a percentage reported as inhibition, at one concentration (the size of the read-out at that concentration, not a potency): 21.8%
Compound 4: the middle estimate sits 9.8 percentage points below what was measured; the measured number falls inside the stated range.
By their numbers in this assay, from the lowest: compounds 2, 3, 4 and 1 (each within the scatter of the next, the first and the last beyond it).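

In this assay, the 3-(trifluoromethyl)phenyl group shows that an aryl group in place of bromo at this aromatic carbon need not lower the number beyond the scatter (a number 2.4 percentage points lower from compound 1 to compound 4 (within the scatter)), unlike the 4-acetylphenyl group of compound 2. Going by these compounds alone, the swap from 4-acetylphenyl to 3-(trifluoromethyl)phenyl is the first aryl-for-aryl change at this carbon to go beyond the scatter (a number 14.2 percentage points higher from compound 2 to compound 4 (beyond the scatter)), so the choice of aryl group can register in this read-out, although the swap from 2-methoxyphenyl stays within it (a number 5.9 percentage points higher from compound 3 to compound 4 (within the scatter)). Nothing measured at hand accounts for the difference between these aryl groups.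

Going by these compounds, compounds 2, 3 and 4 change both the substituent and its place on the phenyl ring at once, so which of the two separates them stays open. Also open, on these data alone, is what an amine or a carboxylic acid on that phenyl ring, or a morpholine ring directly at this carbon, would give in this assay.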